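A few compounds are considered here, and "the series" means these few. Any claim that something is new, unique, unknown or untested is made for them only; others in the source may bear on it.

Three compounds have been measured in a functional assay on HeLa cells (Homo sapiens) for antiproliferative activity, read by MTT assay, with a stated time of 24 h; on this read-out higher numbers stand for weaker inhibition and lower numbers for stronger inhibition:

compound 1, `Brc1ccc(Cc2nnc(Cn3nnc4ccccc43)o2)cc1`, gives 198000 nM;
compound 2, `COc1ccc(Cc2nnc(Cn3nnc4ccccc43)o2)cc1`, gives 150000 nM;
compound 3, `Brc1ccc(-c2nnc(Cn3nnc4ccccc43)o2)cc1`, gives 305000 nM.

Compound 1 and compound 2 differ in one place, (methoxy in place of bromo on an aromatic carbon), and the step this change made is a 1.3-fold lower number from compound 1 to compound 2 (0.12 log units; within the scatter). Compound 3 shares its substituted ring with compound 1 but carries a different core; the difference between the two cores is not broken down here. Compound 3 stands highest of the three numbers, its nearest neighbour being compound 1 and its furthest compound 2.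

The unmeasured compound 4, `COc1ccc(-c2nnc(Cn3nnc4ccccc43)o2)cc1`, stands to compound 3 as compound 2 stands to compound 1: methoxy in place of bromo on an aromatic carbon. The place of the change is described in the same words for both pairs, so it is the same change made on the other core. On the strength of the step from compound 1 to compound 2 in this assay, a step of similar size is expected here, and the step from compound 3 to compound 4 is estimated at a 1.3-fold lower number from compound 3 to compound 4 (0.11 log units; within the scatter). Compound 4 is therefore expected to give about 235000 nM, with a likely range from 120000 nM to 450000 nM.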

Compound 4, half-maximal inhibitory concentration: 269000 nM
Estimate against measurement, compound 4: 1.1-fold (0.06 log units) below; low and high end bracket the measured number.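

In this assay, methoxy in place of bromo on an aromatic carbon gives a 1.1-fold lower number from compound 3 to compound 4 (0.05 log units; within the scatter), and this step agrees with the earlier one: the same change on two cores in this assay, a 1.3-fold lower number (0.12 log units; within the scatter) from compound 1 to compound 2 and a 1.1-fold lower number (0.05 log units; within the scatter) from compound 3 to compound 4, 1.2-fold (0.07 log units) apart, within the scatter of two such steps. Within this small set, then, the change carries from the core of compound 1 to the core of compound 3 with no detectable difference in the size of its step. Both steps lie within the scatter, however, so this is agreement between two small steps, and it neither shows a real effect of the change on either core nor sets a rule for other cores or other assays.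

The compounds shown carry only bromo or methoxy on the six-membered aromatic ring, on just two cores. They leave open what an amine, a carboxylic acid or a longer alkoxy chain would do at that place, and whether any such group would give a step beyond the scatter on either core.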